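The source may hold more compounds than are shown below. What is called first, only, known or untested is meant among the compounds shown, and "the series" means these compounds.

Measured compounds, all in an assay on isolated protein for displacement of a labelled ligand from metabotropic glutamate receptor 5 (Homo sapiens), with a stated time of 60 min, tested at 1 uM; on this read-out higher numbers stand for more inhibition at the one concentration tested (going by the name of the read-out) and lower numbers for less inhibition:
- compound 1, `CC1CCN(c2c(S(=O)(=O)c3ccccc3)cnc3ccccc23)CC1`: compound 1 gives 89.2%
- compound 2, `CC1CCN(c2c(S(=O)(=O)c3ccccc3)cnc3cc(F)ccc23)CC1`: compound 2 gives 87%
- compound 3, `Cc1ccc(S(=O)(=O)c2cnc3cc(F)ccc3c2N2CCC(C)CC2)cc1F`: compound 3 gives 89%

Within the data shown here, the three numbers sit close together, and no pair of them is separated by more than the usual scatter, so none of the three can be set above or below the others.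

Compound 3 differs from compound 2 in the group on the sulfonyl sulfur: 3-fluoro-4-methylphenyl in place of phenyl on a sulfonyl sulfur. That change made a number 2 percentage points higher from compound 2 to compound 3 (within the scatter). Compound 1 differs from compound 2 by hydrogen in place of fluoro on an aromatic carbon; the place is "on an aromatic carbon of a six-membered aromatic ring of carbon only, part of a fused or bridged system of two rings; meta to a fused ring; para to a fused ring". That change made a number 2.2 percentage points higher from compound 2 to compound 1 (within the scatter).

Compound 4, `Cc1ccc(S(=O)(=O)c2cnc3cc(F)ccc3c2N2CCC(C)CC2)cc1`, is not yet measured. Among the measured compounds shown here, it differs from compound 3 by hydrogen in place of fluoro on an aromatic carbon; the place is "on an aromatic carbon of a six-membered aromatic ring of carbon only; ortho to a methyl group (1 heavy atom); meta to a large group", so this is the same kind of change as the one from compound 2 to compound 1, made at a different place. Because that earlier change made a number 2.2 percentage points higher from compound 2 to compound 1 (within the scatter), the step expected here is a number 1 percentage points higher from compound 3 to compound 4 (within the scatter). Compound 4 is therefore estimated at 90% in this assay, with the expected range running from 82% to 96%.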

Compound 4, a percentage reported as inhibition, at one concentration (the size of the read-out at that concentration, not a potency): 88%
Estimate against measurement, compound 4: 2 percentage points above; measured number inside the range.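

In this assay, hydrogen in place of fluoro on an aromatic carbon gives a number 1 percentage points lower from compound 3 to compound 4 (within the scatter), and the change shows no difference that can be read between the two places where it was made: the same change on two cores in this assay, a number 2.2 percentage points higher (within the scatter) from compound 2 to compound 1 and a number 1 percentage points lower (within the scatter) from compound 3 to compound 4, 3.2 percentage points apart, within the scatter of two such steps

Methyl in place of hydrogen on an aromatic carbon gives a number 1 percentage points higher from compound 2 to compound 4 (within the scatter), so the 4-methylphenyl and phenyl groups on the sulfonyl sulfur cannot be told apart here either. Among these compounds, this shows only that neither change moved the read-out beyond the scatter in these compounds; it does not show that either change is without effect on potency, since a percentage at one concentration is not a potency and all four compounds sit close together. Two cases also give no rule for carrying the fluoro-to-hydrogen change to further cores, and the opposite signs of the two steps carry no meaning within the scatter.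

The compounds shown leave open whether a more distant group on the sulfonyl sulfur, such as an aryl group carrying an amine or a carboxylic acid, would separate from this cluster. They also leave open what a longer chain would do in place of the methyl group shared by all four compounds.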